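Iodoacetamide-tethered nucleotides and their inhibition of hexokinase-1

The compounds below may be only part of what the source reports. "The series", "measured", "known", "first", "only" and "open" are said of these compounds alone.

Measured compounds:
compound 1, `Nc1ncnc2c1nc(NCCCCCCCCNC(=O)CI)n2[C@@H]1O[C@H](COP(=O)(O)OP(=O)(O)OP(=O)(O)O)[C@@H](O)[C@H]1O`, 0%
compound 2, `O=C(CI)NCCCCCCCCNc1ncnc2c1ncn2[C@@H]1O[C@H](COP(=O)(O)OP(=O)(O)OP(=O)(O)O)[C@@H](O)[C@H]1O`, 35%
compound 3, `Nc1ncnc2c1nc(NCCCCNC(=O)CI)n2[C@@H]1O[C@H](COP(=O)(O)OP(=O)(O)OP(=O)(O)O)[C@@H](O)[C@H]1O`, 0%

In an assay on isolated protein for inhibition of hexokinase-1 (Rattus norvegicus), with a stated time of 6 h, tested at 10 mM (on this read-out higher numbers stand for more inhibition at the one concentration tested (going by the name of the read-out) and lower numbers for less inhibition), compound 2 gives 35%, the highest of the three numbers, while compound 1 gives 0% and compound 3 gives 0%. The difference between the core of compound 1 and the core of compound 2 is not broken down here. Compound 3 arises from compound 1 by ((iodomethyl)carbonyl)amino in place of 4-(((iodomethyl)carbonyl)amino)butyl on a saturated chain carbon, four bonds along the chain from a nitrogen on an aromatic ring, and this gave no change at the digits printed from compound 1 to compound 3 (within the scatter). Compound 4, `O=C(CI)NCCCCNc1ncnc2c1ncn2[C@@H]1O[C@H](COP(=O)(O)OP(=O)(O)OP(=O)(O)O)[C@@H](O)[C@H]1O`, is not yet measured; it arises from compound 2 by the same change, (((iodomethyl)carbonyl)amino in place of 4-(((iodomethyl)carbonyl)amino)butyl on a saturated chain carbon, four bonds along the chain from a nitrogen on an aromatic ring). For compound 4 in this assay a step of a number 15 percentage points lower from compound 2 to compound 4 (beyond the scatter) is expected, because no change at the digits printed from compound 1 to compound 3 (within the scatter), although that earlier step started from a compound already at the bottom of the read-out and so says little about a compound that starts higher. Compound 4 is therefore estimated at 20%, between 0% and 45%.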

Compound 4, a percentage reported as inhibition, at one concentration (the size of the read-out at that concentration, not a potency): 0%
Compound 4: middle estimate off by 20 percentage points, on the high side; measured number inside the range.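

On the core of compound 2, putting ((iodomethyl)carbonyl)amino in place of 4-(((iodomethyl)carbonyl)amino)butyl gave a number 35 percentage points lower from compound 2 to compound 4 (beyond the scatter) in this assay. The change did not carry over from one core to the other with the same size: the same change on two cores in this assay, no change at the digits printed (within the scatter) from compound 1 to compound 3 and a number 35 percentage points lower (beyond the scatter) from compound 2 to compound 4, 35 percentage points apart, beyond the scatter of two such steps. This does not show how differently the two cores respond to the change, as compound 1 already gives 0%, leaving no room for a drop, and compound 4 ends at the same bottom of the read-out with 0%.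

The compounds shown leave open whether a chain longer than that of compound 2 would give more inhibition. They also leave open what a chloroacetyl group would do in place of the iodoacetyl group.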